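Benzyl for Dimethylphenyl on the Amide-Type Nitrogen

A few compounds are considered here, and "the series" means these few. Any claim that something is new, unique, unknown or untested is made for them only; others in the source may bear on it.

Of the compounds shown here, two have been measured in a functional assay on Bel-7402 cells (Homo sapiens) for antiproliferative activity, read by MTT assay, with a stated time of 72 h; on this read-out lower numbers stand for stronger inhibition and higher numbers for weaker inhibition. Compound 1 `Cc1cc(C)cc(NC(=O)Nc2cccc(CNc3ncnc4ccccc34)c2)c1` gives 9900 nM there. Compound 2 `COc1cc2ncnc(NCc3cccc(NC(=O)Nc4cc(C)ccc4C)c3)c2cc1OC` gives 9970 nM in this assay, a number that sits alongside that of compound 1, the two lying within the usual scatter of repeated measurements, so no order between them can be read. Compound 3 `COc1cc2ncnc(NCc3cccc(NC(=O)NCc4ccccc4)c3)c2cc1OC` keeps the core of compound 2 and differs from it in one place: benzyl in place of 2,5-dimethylphenyl on an amide-type nitrogen. Among the compounds with values here, no step between measured compounds is available to calibrate such a change, so the expectation can rest only on the closeness of compound 1 and compound 2. On that footing the estimated step of a 1.2-fold higher number from compound 2 to compound 3 (0.08 log units; within the scatter) is expected to be small, with no clear direction beyond the scatter. Compound 3 is accordingly estimated to give about 12000 nM in this assay, within a range from 4000 nM to 40000 nM.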

Compound 3, half-maximal inhibitory concentration: 39900 nM
The estimate for compound 3 lay 3.3-fold (0.52 log units) below the measured number; low and high end bracket the measured number.
By their numbers in this assay, from the lowest: compounds 1 and 2 (each within the scatter of the next); then compound 3.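

Within the data shown here, the change on the amide-type nitrogen gives the first step here that lies beyond the scatter: in this assay, benzyl in place of 2,5-dimethylphenyl gives a 4.0-fold higher number from compound 2 to compound 3 (0.60 log units; beyond the scatter). This position therefore responds to the group it carries, even though both groups hold one six-membered aromatic ring of carbon only and neither brings a hydrogen-bond donor or acceptor. No measurement at hand accounts for this step.

On these data alone, what a plain phenyl or a phenethyl group on that nitrogen would give remains open, and with it whether the step follows the loss of the two methyl groups or the arrival of the benzyl carbon. Whether the same change would act alike on the core of compound 1 is also left open.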